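The compounds below may be only part of what the source reports. "The series", "measured", "known", "first", "only" and "open" are said of these compounds alone.

In a functional assay on MCF7 cells (Homo sapiens) for antiproliferative activity, read by MTT assay, with a stated time of 72 h (a lower number here means a stronger inhibitor, a higher number a weaker inhibitor), compound 1 `CC1=CC[C@H]2[C@H](CC[C@]2(C)O)C(C)(C)[C@@H]1CC[C@H]1[C@]2(C)CC[C@H](OC(=O)c3cccc([N+](=O)[O-])c3)C(C)(C)O[C@H]2CC[C@@]1(C)O` gives 36000 nM and compound 2 `CC1=CC[C@H]2[C@H](CC[C@]2(C)O)C(C)(C)[C@@H]1CC[C@H]1[C@]2(C)CC[C@H](OC(=O)c3ccccc3F)C(C)(C)O[C@H]2CC[C@@]1(C)O` gives 11300 nM as the lower of the two numbers. Among the measured compounds shown here, the only measured step is a 3.2-fold lower number from compound 1 to compound 2 (0.50 log units; beyond the scatter) and it is modest, made on a carbonyl carbon with the shared core unchanged. Compound 3 `CC1=CC[C@H]2[C@H](CC[C@]2(C)O)C(C)(C)[C@@H]1CC[C@H]1[C@]2(C)CC[C@H](OC(=O)c3ccc(C(F)(F)F)c(F)c3)C(C)(C)O[C@H]2CC[C@@]1(C)O` changes the group at that same place: 3-fluoro-4-(trifluoromethyl)phenyl in place of 2-fluorophenyl on a carbonyl carbon with 3-fluoro-4-(trifluoromethyl)phenyl in place of 2-fluorophenyl on a carbonyl carbon. For the measured compounds named here, no measured compound carries the entering group, and a single step shows no direction for this change. The step of a 3.2-fold lower number from compound 1 to compound 2 (0.50 log units; beyond the scatter) gives the only available scale, so a shift of that order in this assay remains possible either way, though none beyond the scatter is expected. The estimated change a 1.2-fold higher number from compound 2 to compound 3 (0.06 log units; within the scatter) is therefore small. For compound 3 the estimated value is 13000 nM with an expected range of 5500 nM to 30000 nM in this series.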

Compound 3, half-maximal inhibitory concentration: > 50000 nM
Compound 3: a limit, no number; the forecaster's own chance of this, stated with the estimate: 5%; at least 3.8-fold (0.58 log units) between middle value and limit.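

Compound 3 reads only as a limit, not a number, in this assay: the limit of > 50000 nM in this assay, at which 1 of the 3 values shown sits.

Even so, the place on the carbonyl carbon is shown to move the read-out upward as well as downward, since 3-fluoro-4-(trifluoromethyl)phenyl in place of 2-fluorophenyl gives an at least 4.4-fold higher number from compound 2 to compound 3 (0.64 log units; beyond the scatter). The comparison with the 3-nitrophenyl group is weaker, at an at least 1.3-fold higher number from compound 1 to compound 3 (0.14 log units; that floor lies within the scatter), so no firm order of these two groups follows.

Going by these compounds, whether the trifluoromethyl or the fluorine of the entering group carries the step stays open, as the two enter together. Also open, on these data alone, is whether a group without an aromatic ring at this place, such as an amine or a carboxylic acid, would keep or improve on the number of compound 2, 11300 nM.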